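The compounds below may be only part of what the source reports. "The series", "measured", "known", "first", "only" and "open" are said of these compounds alone.

In a functional assay for antagonist activity, with Homo sapiens as the target (a lower number here means a stronger inhibitor, a higher number a weaker inhibitor), compound 1 `CCCc1cc(OCCCOc2ccc(C(C)=O)c(OC)c2CCC)cc2c1OC(C(=O)O)CC2` gives 1860 nM and compound 2 `CCCc1c(OCCCOc2cc(O)c(C(C)=O)cc2CC)cccc1OCC(=O)O` gives 4390 nM as the higher of the two numbers, a gap beyond the usual scatter. Compound 3 `CCCc1c(OCCCOc2cc(O)c(C(C)=O)cc2CC)cccc1OC(C)C(=O)O` differs from compound 2 by methyl in place of hydrogen on a saturated chain carbon bound to a carbonyl carbon and an oxygen on an aromatic ring with methyl in place of hydrogen on a saturated chain carbon bound to a carbonyl carbon and an oxygen on an aromatic ring. For the measured compounds named here, no measured step covers this change, so only a small shift toward a lower number is expected in this assay and it may stay within the scatter. The estimated change is a 1.4-fold lower number from compound 2 to compound 3 (0.14 log units; within the scatter) as a rough expectation. For compound 3 the estimated value is 3200 nM within an expected range of 1100 nM to 9000 nM on this thin evidence.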

Compound 3, half-maximal inhibitory concentration: 3270 nM
Beside the measured number, compound 3's estimate is 1.0-fold (0.01 log units) below it; the measured number falls inside the stated range.
By their numbers in this assay, from the lowest: compounds 1, 3 and 2 (each within the scatter of the next, the first and the last beyond it).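

In this assay, for the compounds shown here, methyl in place of hydrogen on a saturated chain carbon bound to a carbonyl carbon and an oxygen on an aromatic ring gives a 1.3-fold lower number from compound 2 to compound 3 (0.13 log units; within the scatter) as the first single-place step. Carboxymethoxy and 1-carboxyethoxy therefore read alike here, so this carbon accepts one methyl without a change beyond the scatter. Nothing measured bears on this step. Going by these compounds, whether an ethyl group or a longer chain on this carbon reads the same stays open. So does whether this step holds on another core, since it rests on one pair.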